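Bromo in place of fluoro: expected toxicity of compound 3

This account rests on a few compounds, and the source may have more. Where it says the series, first, only, none or still open, it means among the compounds named here.

Measured compounds:
- compound 1 `Cn1c(-c2ccccc2F)cnc1NC(=O)c1ccc(F)cc1`: in a toxicity assay on THP-1 cells (Homo sapiens) for inhibition (on this read-out higher numbers stand for lower toxicity in this test and lower numbers for higher toxicity in this test), compound 1 reaches only the assay limit > 100000 nM.
- compound 2 `Cn1c(-c2ccccc2)cnc1NC(=O)c1cccc(Cl)c1`: in this assay compound 2 likewise reaches only the assay limit > 50000 nM.

Compound 1 stands at the limit of > 100000 nM in this assay, at which 1 of the 2 values shown sits, not at a number. Compound 2 stands at the limit of > 50000 nM in this assay, at which 1 of the 2 values shown sits. Compound 3 `Cn1c(-c2ccccc2Br)cnc1NC(=O)c1ccc(F)cc1` differs from compound 1 by bromo in place of fluoro on an aromatic carbon. Going by the values given here, no measured pair covers this change, and in this assay no step beyond the scatter is expected in either direction. Compound 3 is therefore expected to show a step of an at least 1.2-fold lower number from compound 1 to compound 3 (0.09 log units; that floor lies within the scatter). The estimate for compound 3 is 80000 nM, expected to lie between 30000 nM and 200000 nM.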

Compound 3, half-maximal cytotoxic concentration: > 100000 nM
Compound 3 gave a limit, no number; the forecaster's own chance of this, stated with the estimate: 60%; middle value at least 1.2-fold (0.09 log units) away from the limit.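

Compound 1 and compound 3 both give only a limit in this assay, so the step between them cannot be read. The compounds shown leave open whether bromo in place of fluoro changes toxicity at all.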